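This account rests on a few compounds, and the source may have more. Where it says the series, first, only, none or still open, it means among the compounds named here.

Of the compounds shown here, three sharing one core have been measured in a physicochemical assay for lipophilicity, read by HPLC, at pH 7.4; on this read-out lower numbers stand for lower lipophilicity and higher numbers for higher lipophilicity. Compound 1 `Cc1cc(OCc2cccc3nccn23)cc(C)c1-c1cccc(COc2ccc3c(c2)OC[C@H]3CC(=O)O)c1` gives 3.8, the second highest of the three numbers. Compound 3 `Cc1nc(C)c(COc2cc(C)c(-c3cccc(COc4ccc5c(c4)OC[C@H]5CC(=O)O)c3)c(C)c2)s1` gives 4.27, and compound 2 `Cc1cc(OCCCS(C)(=O)=O)c(Cl)c(C)c1-c1cccc(COc2ccc3c(c2)OC[C@H]3CC(=O)O)c1` gives the lowest, 3.07. Compound 4 `CCS(=O)(=O)CCOc1cc(C)c(-c2cccc(COc3ccc4c(c3)OC[C@H]4CC(=O)O)c2)c(C)c1` has not yet been measured and differs from compound 1 in one place: a group of 6 heavy atoms (3 carbon, 2 oxygen, 1 sulfur; no ring) in place of a group of 9 heavy atoms (7 carbon, 2 nitrogen; one five-membered aromatic ring with 2 hetero atoms, one six-membered aromatic ring with 1 hetero atom), on a saturated chain carbon bound to an oxygen on an aromatic ring. The group that enters is (ethylsulfonyl)methyl.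

Within the data shown here, the only measured step at this place is a number 0.47 log units higher from compound 1 to compound 3 (beyond the scatter). That step replaces one ring-bearing group with another, so it says little about a group with no ring. Compound 2 is the closer comparison, with a sulfonyl-bearing chain and no ring there, although it also differs from compound 1 elsewhere. Compound 2, with 3.07, lies beyond the scatter below compound 1, so a downward step of similar size is expected. The expected step is a number 0.85 log units lower from compound 1 to compound 4 (beyond the scatter). For compound 4 the estimated value is 2.95, with an expected range from 2.55 to 3.35.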

Compound 4, distribution coefficient: 2.73
For compound 4 the middle estimate is 0.22 log units above the measured one, and the stated range covers the measured number.
By their numbers in this assay, from the lowest: compound 4; then compound 2; then compound 1; then compound 3.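

Putting (ethylsulfonyl)methyl on the saturated chain carbon bound to an oxygen on an aromatic ring gives a number 1.07 log units lower from compound 1 to compound 4 (beyond the scatter) and a number 1.54 log units lower from compound 3 to compound 4 (beyond the scatter) in this assay. Among these compounds, both steps are large, whereas the one earlier step at this place, a number 0.47 log units higher from compound 1 to compound 3 (beyond the scatter), exchanged one ring-bearing group for another, so this position is now seen to carry a much wider span of read-outs than that step showed. No measured evidence bears on the size of these steps.

The compounds shown leave open whether the steps go with the loss of the ring or with the presence of the sulfonyl group. A plain butyl chain or an amine at the same place would begin to separate the two.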